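Pyridin-3-yl in place of pyridin-4-yl: working notes

This account rests on a few compounds, and the source may have more. Where it says the series, first, only, none or still open, it means among the compounds named here.

In an ADME assay on a cell-free system (plasma, Homo sapiens) for protein binding, read by LC-MS, tested at 5 uM (a lower number here means a smaller unbound share, a higher number a larger unbound share of the compound), compound 1 (`CS(=O)(=O)NC(=O)CCc1cn(-c2ccc(Br)cc2)nc1-c1ccc(Cl)cc1`) gives 0.00004 and compound 2 (`CS(=O)(=O)NC(=O)CCc1cn(-c2ccc(Cl)cc2)nc1-c1ccc(Cl)cc1`) gives 0.00023 while compound 3 (`CS(=O)(=O)NC(=O)CCc1cn(-c2ccc(Br)cc2)nc1-c1ccncc1`) gives 0.00009 in the same measurement. Compound 3 therefore holds the second highest of the three numbers, with compound 1 under it and compound 2 over it. Compound 4 (`CS(=O)(=O)NC(=O)CCc1cn(-c2ccc(Br)cc2)nc1-c1cccnc1`) is the next structure, with pyridin-3-yl in place of pyridin-4-yl on an aromatic carbon. The change is pyridin-3-yl in place of pyridin-4-yl on an aromatic carbon and leaves the same atoms, joined differently. Among the compounds with values here, two measured steps bear on it, both modest. The closer is a 2.3-fold higher number from compound 1 to compound 3 (0.35 log units; beyond the scatter) for pyridin-4-yl in place of 4-chlorophenyl at the same place. The other is a 5.8-fold higher number from compound 1 to compound 2 (0.76 log units; beyond the scatter) for chloro in place of bromo and serves only as a gauge of how far numbers move here. Within the data shown here, no measured pair shows an exchange of pyridin-4-yl for pyridin-3-yl. The expected size is a 1.1-fold higher number from compound 3 to compound 4 (0.05 log units; within the scatter) and no step beyond the scatter is expected, in either direction. For compound 4 the estimated value is 0.0001 with an expected range from 0.00004 to 0.00025 on this read-out.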

Compound 4, unbound fraction: 0.00022
The estimate for compound 4 lay 2.2-fold (0.34 log units) below the measured number; the range from low to high includes it.
By their numbers in this assay, from the lowest: compound 1; then compound 3; then compounds 4 and 2 (each within the scatter of the next).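

In this assay this place on the five-membered aromatic ring distinguishes between the two pyridine isomers: with the same atoms joined differently, pyridin-3-yl in place of pyridin-4-yl gives a 2.4-fold higher number from compound 3 to compound 4 (0.39 log units; beyond the scatter) on its own. The replacement of 4-chlorophenyl therefore depends on which isomer enters, as pyridin-3-yl gives a 5.5-fold higher number from compound 1 to compound 4 (0.74 log units; beyond the scatter) at the same place. Nothing available bears on why the two isomers differ.

Open, from the compounds shown here alone, is whether pyridin-2-yl or pyrimidin-5-yl at this place would continue the same trend, and whether the isomer step would carry over with a 4-chlorophenyl group in place of the 4-bromophenyl group. Also open, going by these compounds, is how either pyridine would behave with a carboxylic acid in place of the 2-((methylsulfonyl)carbamoyl)ethyl group's acylsulfonamide end.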